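The source may hold more compounds than are shown below. What is called first, only, known or untested is meant among the compounds shown, and "the series" means these compounds.

Among the compounds with values here, in a functional assay on DU-145 cells (Homo sapiens) for cytotoxicity (a lower number here means a stronger inhibitor of growth, a higher number a weaker inhibitor of growth), compound 2 `CSc1ccc(C2=C(c3ccc(F)c(F)c3)C(=O)N3CCCC3C2)cc1` gives 500 nM and holds the lower of the two numbers so far. Within the data shown here, the only other measured compound is compound 1 `COc1ccc(C2=C(c3ccc(SC)cc3)CC3CCCN3C2=O)cc1O` with 6000 nM as its number. Compound 3 `CSc1ccc(C2=C(c3ccc(C)c(C)c3)C(=O)N3CCCC3C2)cc1` has not yet been measured. It carries 3,4-dimethylphenyl in place of 3,4-difluorophenyl on a double-bonded ring carbon, and the swap 3,4-dimethylphenyl in place of 3,4-difluorophenyl on a double-bonded ring carbon leaves the rest of compound 2 unchanged. Among the measured compounds shown here, the one measured step at this place is a 12-fold lower number from compound 1 to compound 2 (1.08 log units; beyond the scatter) with 3,4-difluorophenyl replacing 3-hydroxy-4-methoxyphenyl, which is large and beyond the scatter. For the measured compounds named here, that step shows this place can matter, but it involved a different pair of groups, and no measured pair compares the two groups now exchanged. No step beyond the scatter is therefore expected in this assay for this swap. The expected step is a 1.4-fold higher number from compound 2 to compound 3 (0.15 log units; within the scatter) by this estimate. For compound 3 the estimated value is 700 nM with an expected range from 200 nM to 2500 nM around it.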

Compound 3, concentration for 50% growth inhibition: 500 nM
Beside the measured number, compound 3's estimate is 1.4-fold (0.15 log units) above it; the measured number falls inside the stated range.
By their numbers in this assay, from the lowest: compounds 2 and 3 (each within the scatter of the next); then compound 1.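

For this assay the exchange at the double-bonded ring carbon shows no change at the digits printed from compound 2 to compound 3 (within the scatter) and so separates 3,4-dimethylphenyl from 3,4-difluorophenyl by nothing beyond the scatter. Compound 3 also shows a 12-fold lower number from compound 1 to compound 3 (1.08 log units; beyond the scatter) and so the large gain from the 3-hydroxy-4-methoxyphenyl group of compound 1 does not depend on fluorine, since it appears with either group among these three compounds. Nothing at hand explains why the two groups give the same number. On these data alone, what remains open is whether that number holds when this phenyl ring carries an amine or a carboxylic acid, or no substituent at all. As far as these compounds go, it is also open whether a single methyl or a single fluorine on the ring would serve as well as the pairs seen here.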